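The compounds below may be only part of what the source reports. "The series", "measured", "known", "first", "only" and "open" are said of these compounds alone.

Of the compounds shown here, three sharing one core have been measured in a functional assay on AGS cells (Homo sapiens) for cytotoxicity, read by MTT assay, with a stated time of 48 h; on this read-out lower numbers stand for stronger inhibition and higher numbers for weaker inhibition. Compound 1 `Cc1nc2c3ccccc3ccc2c2nc3c(ccc4ccccc43)c(-c3cccnc3)c12` gives 3960 nM, compound 2 `Cc1nc2c3ccccc3ccc2c2nc3c(ccc4ccccc43)c(-c3cc([N+](=O)[O-])ccc3N)c12` gives 17800 nM, and compound 3 `Cc1nc2c3ccccc3ccc2c2nc3c(ccc4ccccc43)c(-c3ccccc3N)c12` gives 12100 nM. Among these numbers compound 3 stands second highest: its nearest neighbour is compound 2, a gap within the scatter, and its furthest is compound 1, a gap beyond the scatter. Compound 4 `Cc1nc2c3ccccc3ccc2c2nc3c(ccc4ccccc43)c(-c3ccccc3S)c12` has not yet been measured. It differs from compound 3 by sulfanyl in place of amino on an aromatic carbon, an exchange of one heavy atom for another on an aromatic carbon of a six-membered aromatic ring of carbon only. Among the compounds with values here, no measured step exchanges these two groups. The steps that touch the same pendant ring were a 3.1-fold higher number from compound 1 to compound 3 (0.49 log units; beyond the scatter) and a 1.5-fold lower number from compound 2 to compound 3 (0.17 log units; within the scatter), the second of which stayed within the scatter. On this basis the step of a 1.0-fold lower number from compound 3 to compound 4 (0.00 log units; within the scatter) is expected to be small, in no clear direction, and probably not beyond the scatter. Compound 4 is therefore estimated at 12000 nM, with a range from 5000 nM to 30000 nM.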

Compound 4, half-maximal inhibitory concentration: 4070 nM
Compound 4: the middle estimate sits 2.9-fold (0.47 log units) above what was measured; measured number below the stated range.
By their numbers in this assay, from the lowest: compounds 1 and 4 (each within the scatter of the next); then compounds 3 and 2 (each within the scatter of the next).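

In this assay, sulfanyl in place of amino gives a 3.0-fold lower number from compound 3 to compound 4 (0.47 log units; beyond the scatter), so this position responds to a single-atom exchange even though the group that leaves and the group that enters have the same counts of hydrogen-bond donors and acceptors. Within the data shown here, until now, the only change made on a substituted phenyl ring, the loss of nitro, had stayed within the scatter. The 2-sulfanylphenyl group also gives a 4.4-fold lower number from compound 2 to compound 4 (0.64 log units; beyond the scatter), while a 1.0-fold higher number from compound 1 to compound 4 (0.01 log units; within the scatter) lies within the scatter, showing that a substituted phenyl ring here can match the pyridin-3-yl group.

Nothing available explains why sulfur and nitrogen differ at this position. As far as these compounds go, whether a hydroxyl group in the same place would track sulfanyl or amino also remains open.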